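The source may hold more compounds than are shown below. What is called first, only, known or untested is meant among the compounds shown, and "the series" means these compounds.

Among the compounds with values here, in a functional assay on MDA-MB-231 cells (Homo sapiens) for inhibition, read by MTT assay, with a stated time of 48 h (on this read-out higher numbers stand for weaker inhibition and lower numbers for stronger inhibition), compound 1 (`COc1cc(/C=C/C(=O)NO)ccc1OCC(=O)Nc1ccccc1F`) gives 8300 nM as the only true number among the three compounds measured so far. Compound 2 (`COc1cc(/C=C/C(=O)Nc2ccccc2N)ccc1OCC(=O)Nc1cccc(F)c1`) returns only a limit in this assay with > 100000 nM as its entry. Compound 3 (`COc1cc(/C=C/C(=O)Nc2ccc(C)cc2N)ccc1OCC(=O)Nc1cc(Br)cc(C(F)(F)F)c1`) also returns only a limit, with > 100000 nM as its entry in this assay. Compound 1 is therefore the sole quantified point on the scale, and the other two readings (the limit of > 100000 nM in this assay, at which 2 of the 3 values shown sit) supply no measured step to reason from.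

Compound 4 (`COc1cc(/C=C/C(=O)NO)ccc1OCC(=O)Nc1ccc(Br)cc1`) keeps the core of compound 1 and alters one group: 4-bromophenyl in place of 2-fluorophenyl on an amide-type nitrogen puts 4-bromophenyl in place of 2-fluorophenyl on an amide-type nitrogen. Within the data shown here, no measured pair shows what such an exchange does in this assay and the expectation has to rest on compound 1 and its 8300 nM reading alone. With the rest of the structure unchanged, the expected 1.2-fold lower number from compound 1 to compound 4 (0.07 log units; within the scatter) stays within the usual scatter of such measurements, with no direction favoured. For compound 4 the estimated half-maximal inhibitory concentration is 7000 nM with an expected range from 2500 nM to 22000 nM in this estimate.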

Compound 4, half-maximal inhibitory concentration: 760 nM
Compound 4: middle estimate off by 9.2-fold (0.96 log units), on the high side; the whole stated range lies above it.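

In this assay, within the data shown here, the exchange of 2-fluorophenyl for 4-bromophenyl on the amide-type nitrogen gives an 11-fold lower number from compound 1 to compound 4 (1.04 log units; beyond the scatter) on the shared core, the first measured step in this set. It shows that the read-out responds strongly to the aryl group at this place, even though the two groups have the same heavy-atom count, the same six-membered aromatic ring of carbon only, no hydrogen-bond donors or acceptors and no net charge, so that they differ only in the halogen and where it stands on the ring. Nothing among the data shown accounts for the size of this step.

Among these compounds, the single step changes the halogen and its place on the ring together, so it cannot say which of the two carries the change; a 4-fluorophenyl or a 2-bromophenyl group on this nitrogen would separate them. It also leaves open whether the halogen is needed at all, which an unsubstituted phenyl group or a 4-methoxyphenyl group at the same place would begin to answer.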